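Cyclohexyl on the amide-type nitrogen of compound 3

The source may hold more compounds than are shown below. What is called first, only, known or untested is meant among the compounds shown, and "the series" means these compounds.

In a functional assay on K562 cells (Homo sapiens) for antiproliferative activity, read by MTT assay (a higher number here means a weaker inhibitor, a lower number a stronger inhibitor), compound 1 (`COC(=O)N1CCCc2cc(S(=O)(=O)N3CC(c4ccccc4)NC3=O)ccc21`) reports only a limit (> 20000 nM). Compound 2 (`O=C(c1ccccc1)N1CCCc2cc(S(=O)(=O)N3CC(c4ccccc4)NC3=O)ccc21`) gives 1220 nM. Compound 3 (`NC(=O)N1CCCc2cc(S(=O)(=O)N3CC(c4ccccc4)NC3=O)ccc21`) gives 3660 nM, the higher of the two real numbers. Compound 4 (`O=C(NC1CCCCC1)N1CCCc2cc(S(=O)(=O)N3CC(c4ccccc4)NC3=O)ccc21`) has cyclohexyl in place of hydrogen on an amide-type nitrogen. Changes on the same carbonyl carbon bear on this. Phenyl in place of methoxy was a large step (an at least 16-fold lower number from compound 1 to compound 2 (1.21 log units; beyond the scatter)), and amino in place of methoxy was at least modest (an at least 5.4-fold lower number from compound 1 to compound 3 (0.73 log units; beyond the scatter)). Amino in place of phenyl was a modest step upward (a 3.0-fold higher number from compound 2 to compound 3 (0.48 log units; beyond the scatter)), so the ring-bearing compound 2 sits lower. A modest drop is therefore expected (a 2.3-fold lower number from compound 3 to compound 4 (0.36 log units; beyond the scatter)). For compound 4 the estimate is 1600 nM, within an expected range of 450 nM to 6000 nM.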

Compound 4, half-maximal inhibitory concentration: 813 nM
Compound 4: middle estimate off by 2.0-fold (0.29 log units), on the high side; low and high end bracket the measured number.
By their numbers in this assay, from the lowest: compounds 4 and 2 (each within the scatter of the next); then compound 3. At a limit, above all of these: compound 1.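

In this assay, cyclohexyl on the amide-type nitrogen gives a 4.5-fold lower number from compound 3 to compound 4 (0.65 log units; beyond the scatter) and so shows that this nitrogen tolerates a six-carbon ring, with a gain over the bare amino group. Cyclohexylamino and phenyl on the carbonyl carbon stay level, with a 1.5-fold lower number from compound 2 to compound 4 (0.18 log units; within the scatter) as the step, so these two different ring-bearing groups cannot be told apart here. Cyclohexylamino in place of methoxy gives an at least 24-fold lower number from compound 1 to compound 4 (1.39 log units; beyond the scatter) as a bound only, and the value of compound 1 is a limit: the limit of > 20000 nM in this assay, at which 1 of the 4 values shown sits.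

As far as these compounds go, whether a small methyl or an open n-hexyl chain on this nitrogen would do as well remains open. So does whether a phenyl ring or a piperidine there would match cyclohexyl.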